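From Propargyl to Benzyl: An Open Step

This account rests on a few compounds, and the source may have more. Where it says the series, first, only, none or still open, it means among the compounds named here.

In an ADME assay on HII4E cells (Mus musculus) for cytotoxicity, read by MTT assay, with a stated time of 48 h (on this read-out lower numbers stand for stronger inhibition and higher numbers for weaker inhibition), compound 1 `C=CCNC(=O)CO[C@H]1O[C@H](COC(C)=O)C=C(OC(C)=O)/C1=C\C(=O)OCC` gives 352 ug/mL and compound 2 `C#CCNC(=O)CO[C@H]1O[C@H](COC(C)=O)C=C(OC(C)=O)/C1=C\C(=O)OCC` gives 257 ug/mL, so these two numbers stand within the scatter of each other. Compound 3 `CCOC(=O)/C=C1\C(OC(C)=O)=C[C@@H](COC(C)=O)O[C@@H]1OCC(=O)NCc1ccccc1` keeps the shared core and differs from compound 2 at one place: phenyl in place of ethynyl on a saturated chain carbon bound to an amide-type nitrogen. Put another way, propargyl becomes benzyl. For the measured compounds named here, only one measured step bears on this, a 1.4-fold lower number from compound 1 to compound 2 (0.14 log units; within the scatter), made on the same carbon. Going by the values given here, no phenyl group has yet been measured there, so the evidence is thin. No step beyond the scatter is therefore expected in this assay, in either direction. The expected step is a 1.1-fold lower number from compound 2 to compound 3 (0.03 log units; within the scatter). Compound 3 is expected at 240 ug/mL, with an estimated range of 110 ug/mL to 500 ug/mL.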

Compound 3, half-maximal inhibitory concentration: 128 ug/mL
For compound 3 the middle estimate is 1.9-fold (0.27 log units) above the measured one; the range from low to high includes it.
By their numbers in this assay, from the lowest: compounds 3, 2 and 1 (each within the scatter of the next, the first and the last beyond it).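

In this assay, phenyl in place of ethynyl on a saturated chain carbon bound to an amide-type nitrogen gives a 2.0-fold lower number from compound 2 to compound 3 (0.30 log units; within the scatter) and so leaves compound 3 level with compound 2 on this read-out. Phenyl in place of vinyl at the same place gives a 2.8-fold lower number from compound 1 to compound 3 (0.44 log units; beyond the scatter) as the first modest step beyond the scatter at this position, although compound 3, compound 2 and compound 1 each stay within the scatter of their neighbour in the order of their numbers. No measurement shown explains either step.

From the compounds shown here alone, whether the step from compound 1 to compound 3 depends on the aromatic ring itself stays open, and cyclohexyl at the same place would test that. Going by these compounds, a carboxylic acid or an amine on the phenyl ring, or a longer chain between that ring and the amide-type nitrogen, also remains open.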